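A few compounds are considered here, and "the series" means these few. Any claim that something is new, unique, unknown or untested is made for them only; others in the source may bear on it.

Compound 3 `CCC/C=C/C(=O)N(Cc1ccc(OC)c(O)c1)c1cc(OC)c(OC)c(OC)c1` is the compound to keep in view here. In a functional assay on KYSE-450 cells (Homo sapiens) for inhibition, read by MTT assay, with a stated time of 48 h (on this read-out lower numbers stand for stronger inhibition and higher numbers for weaker inhibition), compound 3 gives 57 nM, which is the lowest of the two numbers on hand. Compound 1 `COc1ccc(CNc2cc(OC)c(OC)c(OC)c2)cc1[N+](=O)[O-]` gives in this assay 16800 nM, a step up that lies far beyond the scatter of repeated measurements. Compound 2 `COc1cc(NCc2ccc(Cl)cc2)cc(OC)c1OC` gives in this assay only > 80000 nM, which is a limit of the assay and not a number; this is the limit of > 80000 nM in this assay, at which 1 of the 3 values shown sits.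

Compound 4 `C/C=C/C(=O)N(Cc1ccc(OC)c(O)c1)c1cc(OC)c(OC)c(OC)c1` has not yet been measured. It differs from compound 3 in one place: hydrogen in place of ethyl on a saturated chain carbon bound to a double-bonded chain carbon. Read one bond further out, the (pent-1-en-1-yl)carbonyl of compound 3 becomes a (prop-1-en-1-yl)carbonyl in compound 4. Going by the values given here, no measured pair in this set shows a change of this kind, so any expectation rests on compound 3 alone. The change is estimated to produce a step of a 1.9-fold higher number from compound 3 to compound 4 (0.29 log units; within the scatter), at most a modest loss and possibly none beyond the scatter. Compound 4 is therefore expected to give about 110 nM, with a likely range from 30 nM to 450 nM.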

Compound 4, half-maximal inhibitory concentration: 67 nM
The estimate for compound 4 lay 1.6-fold (0.22 log units) above the measured number, within the range that was stated.
By their numbers in this assay, from the lowest: compounds 3 and 4 (each within the scatter of the next); then compound 1. At a limit, above all of these: compound 2.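

In this assay, replacing the (pent-1-en-1-yl)carbonyl with a (prop-1-en-1-yl)carbonyl gives a 1.2-fold higher number from compound 3 to compound 4 (0.07 log units; within the scatter) and so leaves two numbers that cannot be told apart. Going by these compounds alone, this is the first pair here that differs in one place, and it shows that, for these two compounds, hydrogen can stand in place of ethyl on this saturated chain carbon with no difference this assay can resolve. Nothing measured for these compounds offers a reason for this result.

Open, going by these compounds, is whether a longer chain at this place, or an amine or a carboxylic acid at its end, would also leave the number unchanged. Both compounds of the pair keep the double-bonded chain carbons, so the pair cannot say whether a fully saturated chain would serve as well.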